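Tetrazolyl in place of pyrimidinyl on the sulfur

This account rests on a few compounds, and the source may have more. Where it says the series, first, only, none or still open, it means among the compounds named here.

Measured compounds in a functional assay on C6 cells (Rattus norvegicus) for cytotoxicity, read by MTT assay, with a stated time of 24 h, tested at 25 ug/mL; a lower number here means a stronger effect, a higher number a weaker effect of the compound at the concentration tested:
Compound 1 `Cc1ccc(-c2cs/c(=N/NC(=O)CSc3nnnn3-c3ccccc3)n2-c2ccccc2)cc1`: 38.8%
Compound 2 `O=C(CSc1ncccn1)N/N=c1/scc(-c2ccc(F)cc2)n1-c1ccccc1`: 63.9%
Compound 3 `COc1ccc(-c2cs/c(=N/NC(=O)CSc3ncccn3)n2-c2ccccc2)cc1`: 74%

Compound 2 stands second highest of the three numbers in this assay. Its nearest neighbour is compound 3, reached by the step of a number 10.1 percentage points higher from compound 2 to compound 3 (beyond the scatter), which goes with methoxy in place of fluoro on an aromatic carbon; its furthest is compound 1, a lower number beyond the scatter.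

Compound 4 `O=C(CSc1nnnn1-c1ccccc1)N/N=c1/scc(-c2ccc(F)cc2)n1-c1ccccc1` is not yet measured. It differs from compound 2 in one place: 1-phenyl-1H-tetrazol-5-yl in place of pyrimidin-2-yl on a sulfur.

Among the compounds with values here, the only measured step, from compound 2 to compound 3, changes the aryl substituent and leaves the group on the sulfur untouched, so it does not bear on this change. Within the data shown here, compound 1 is the only measured compound carrying the entering group, but it also differs from compound 2 at the aryl, so no single step connects them; what its two values show is that the tetrazolyl-bearing compound gives the lowest number of the three.

On that footing a lower number for compound 4 is expected, a step of a number 18.9 percentage points lower from compound 2 to compound 4 (beyond the scatter) in this assay, beyond the scatter but uncertain in size. The estimate for compound 4 is 45%, with a range of 30% to 65%.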

Compound 4, a percentage reported as activity, at one concentration (the size of the read-out at that concentration, not a potency): 49.3%
Estimate against measurement, compound 4: 4.3 percentage points below; measured number inside the range.
By their numbers in this assay, from the lowest: compound 1; then compound 4; then compound 2; then compound 3.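

In this assay the group on the sulfur can now be read on its own: with the fluoro aryl held fixed, 1-phenyl-1H-tetrazol-5-yl in place of pyrimidin-2-yl gives a number 14.6 percentage points lower from compound 2 to compound 4 (beyond the scatter) and so moves the number toward a stronger effect. With the tetrazolyl group held fixed, fluoro in place of methyl gives a number 10.5 percentage points higher from compound 1 to compound 4 (beyond the scatter) and shows that the aryl substituent also changes the read-out in this second sulfur series, as it did among the pyrimidinyl compounds with a number 10.1 percentage points higher from compound 2 to compound 3 (beyond the scatter). The low number of compound 1 therefore does not rest on the tetrazolyl group alone, since its methyl group accounts for part of its separation from compound 4.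

Whether the sulfur and aryl changes add up remains open, as the methyl group is shown only with the tetrazolyl group and the methoxy group only with the pyrimidinyl group, and 1-methyl-1H-tetrazol-5-yl on the sulfur would help separate the contribution of the tetrazole ring from that of its phenyl group. No measurement among the data shown gives a reason for these steps.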